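The source may report more compounds than this note shows. Statements on the series, on what has been measured and on what is new or still open speak of the compounds shown alone.

Series: one shared core carrying a substituted anilino group and a five-carbon chain that ends in a sulfonamide-bearing anilide. Compound 1 `COc1cc2ncnc(Nc3ccc(F)cc3)c2cc1OCCCCC(=O)Nc1ccc(S(N)(=O)=O)cc1` carries a 4-fluorophenyl group. In a functional assay on A549 cells (Homo sapiens) for antiproliferative activity, read by MTT assay, with a stated time of 72 h (on this read-out lower numbers stand for stronger inhibition and higher numbers for weaker inhibition), compound 1 gives only a limit, > 40000 nM. Compound 2 `COc1cc2ncnc(Nc3ccc(Br)cc3)c2cc1OCCCCC(=O)Nc1ccc(S(N)(=O)=O)cc1` carries a 4-bromophenyl group. In this assay compound 2 likewise gives only a limit, > 40000 nM. Compound 3 `COc1ccc(Nc2ncnc3cc(OC)c(OCCCCC(=O)Nc4ccc(S(N)(=O)=O)cc4)cc23)cc1OC` carries a 3,4-dimethoxyphenyl group. In this assay compound 3 also gives only a limit, > 40000 nM. For the measured compounds named here, compound 2 thus stands where every value so far stands, at the limit of > 40000 nM in this assay, at which 3 of the 3 values shown sit, and no number is known for it. The steps a step that the two limits leave unreadable from compound 1 to compound 2, a step that the two limits leave unreadable from compound 1 to compound 3 and a step that the two limits leave unreadable from compound 2 to compound 3 are accordingly unreadable in size and direction.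

Compound 4 `COc1cc2ncnc(Nc3ccc(C)cc3)c2cc1OCCCCC(=O)Nc1ccc(S(N)(=O)=O)cc1` differs from compound 2 by methyl in place of bromo on an aromatic carbon. Going by the values given here, the one step that bears on this change, a step that the two limits leave unreadable from compound 1 to compound 2, gives no size, so nothing in this assay points to a gain or a loss beyond the scatter. Compound 4 is therefore expected to remain at the limit, with the step that the limit leaves unreadable from compound 2 to compound 4 estimated as none readable. Compound 4 is estimated at 60000 nM, within 15000 nM to 200000 nM.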

Compound 4, half-maximal inhibitory concentration: > 40000 nM
Compound 4 was reported as a limit; the forecaster's own chance of this, stated with the estimate: 85%; the middle value is on the limit's open side.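

Compound 4, like compound 1, compound 2 and compound 3, gives only a limit, so no step among these compounds can be read in size or direction in this assay: the limit of > 40000 nM in this assay, at which 4 of the 4 values shown sit.

Left open is whether these anilino groups differ at all in their antiproliferative activity, and how the four compounds rank against one another.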